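Amide chain variation on the trimethoxyphenyl series

The source may report more compounds than this note shows. Statements on the series, on what has been measured and on what is new or still open speak of the compounds shown alone.

Of the compounds shown here, three have been measured in a functional assay on KYSE-450 cells (Homo sapiens) for inhibition, read by MTT assay, with a stated time of 48 h; on this read-out higher numbers stand for weaker inhibition and lower numbers for stronger inhibition. Compound 1 `COc1ccc(CN(C(=O)CCCl)c2cc(OC)c(OC)c(OC)c2)cc1O` gives 110 nM. Compound 2 `C/C=C/C(=O)N(Cc1ccc(OC)c(N)c1)c1cc(OC)c(OC)c(OC)c1` gives 310 nM. Going by the values given here, compound 3 `CCCCC(=O)N(Cc1ccc(OC)c(O)c1)c1cc(OC)c(OC)c(OC)c1` gives 300 nM, which is the second highest of the three numbers; its gap to compound 2 lies within the scatter, while the single measured step of a 2.7-fold higher number from compound 1 to compound 3 (0.44 log units; beyond the scatter) lies beyond it.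

The next compound, compound 4 `C/C=C/C(=O)N(Cc1ccc(OC)c(O)c1)c1cc(OC)c(OC)c(OC)c1`, differs from compound 3 only at the carbonyl carbon: prop-1-en-1-yl in place of butyl on a carbonyl carbon. Among the compounds with values here, no measured step covers this change directly. Compound 2 carries the same prop-1-en-1-yl carbonyl as compound 4 but an amino group in place of the hydroxyl, and its value sits within the scatter of compound 3, so the chain exchange alone has not shown a large effect here. The step of a 2.7-fold higher number from compound 1 to compound 3 (0.44 log units; beyond the scatter) concerns a different part of the chain and bears on it only loosely.

Compound 4 is therefore expected to land close to compound 3, with the step of a 1.2-fold lower number from compound 3 to compound 4 (0.08 log units; within the scatter) not expected to exceed the scatter. The estimate for compound 4 in this assay is 250 nM, ranging from 100 nM to 600 nM.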

Compound 4, half-maximal inhibitory concentration: 67 nM
Estimate against measurement, compound 4: 3.7-fold (0.57 log units) above, and the stated range ends above it.
By their numbers in this assay, from the lowest: compounds 4 and 1 (each within the scatter of the next); then compounds 3 and 2 (each within the scatter of the next).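

At the carbonyl carbon in this assay, prop-1-en-1-yl in place of butyl gives a 4.5-fold lower number from compound 3 to compound 4 (0.65 log units; beyond the scatter) with the rest of the molecule unchanged, so this position does respond to the chain. With prop-1-en-1-yl held in place, hydroxy in place of amino on the aromatic carbon gives a 4.6-fold lower number from compound 2 to compound 4 (0.67 log units; beyond the scatter) as a separate step, so the aromatic substituent counts as well. Prop-1-en-1-yl in place of 2-chloroethyl gives a 1.6-fold lower number from compound 1 to compound 4 (0.22 log units; within the scatter) and does not separate those two chains, and no measurement at hand explains any of these steps.

Prop-1-en-1-yl differs from butyl in both chain length and the double bond, and a saturated propyl chain on the carbonyl carbon would tell these apart. On these data alone, whether the step from amino to hydroxy holds with butyl on the carbonyl carbon also remains open.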